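From Piperidin-1-yl to (Piperidin-1-yl)amino on a Carbonyl Carbon

A few compounds are considered here, and "the series" means these few. Any claim that something is new, unique, unknown or untested is made for them only; others in the source may bear on it.

Among the compounds with values here, in a physicochemical assay for solubility, read by HPLC, in phosphate buffer, measured as kinetic solubility, at pH 7.4 (on this read-out lower numbers stand for lower solubility and higher numbers for higher solubility), three compounds on one shared core have numbers so far. Compound 1 `CCC(=O)c1cc(-c2ccc(S(N)(=O)=O)cc2)n(-c2ccc(Cl)cc2)n1` gives 41900 nM and compound 2 `CCCC(=O)c1cc(-c2ccc(S(N)(=O)=O)cc2)n(-c2ccc(Cl)cc2)n1` gives 25800 nM while compound 3 `NS(=O)(=O)c1ccc(-c2cc(C(=O)N3CCCCC3)nn2-c2ccc(Cl)cc2)cc1` gives 65900 nM on the same scale. Compound 3 cannot be told apart from compound 1 but stands clear of compound 2, the only such gap among the three. Compound 4 `NS(=O)(=O)c1ccc(-c2cc(C(=O)NN3CCCCC3)nn2-c2ccc(Cl)cc2)cc1` has no number yet. It differs from compound 3 in one place, with (piperidin-1-yl)amino in place of piperidin-1-yl on a carbonyl carbon, counted as (piperidin-1-yl)amino in place of piperidin-1-yl on a carbonyl carbon at that carbon. Within the data shown here, no measured step makes this exact change. The nearest guides are the swaps on the same carbonyl carbon, namely a 1.6-fold higher number from compound 1 to compound 3 (0.20 log units; within the scatter) and a 2.6-fold higher number from compound 2 to compound 3 (0.41 log units; beyond the scatter) for ethyl and propyl giving way to piperidin-1-yl, while the methyl step a 1.6-fold lower number from compound 1 to compound 2 (0.21 log units; within the scatter) is the only other one available. On that evidence no step beyond the scatter is expected in this assay for this change, with the direction leaning slightly lower. The expected step is a 1.4-fold lower number from compound 3 to compound 4 (0.14 log units; within the scatter) in this estimate. For compound 4 the estimated value is 48000 nM with an expected range from 18000 nM to 110000 nM as its bounds.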

Compound 4, solubility: 53700 nM
Estimate against measurement, compound 4: 1.1-fold (0.05 log units) below; low and high end bracket the measured number.
By their numbers in this assay, from the lowest: compounds 2, 1, 4 and 3 (each within the scatter of the next, the first and the last beyond it).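

In this assay the carbonyl carbon takes the extra nitrogen of (piperidin-1-yl)amino, with the hydrogen-bond donor and acceptor counted for that group, and the outcome is a 1.2-fold lower number from compound 3 to compound 4 (0.09 log units; within the scatter), so this read-out does not tell the two groups apart. Compound 4 also relates to the two chain compounds as compound 3 does, with a 2.1-fold higher number from compound 2 to compound 4 (0.32 log units; beyond the scatter) for propyl giving way and a 1.3-fold higher number from compound 1 to compound 4 (0.11 log units; within the scatter) for ethyl giving way, so that on this carbonyl carbon both groups bearing the piperidine ring stand clear of propyl and neither stands clear of ethyl. Nothing given here accounts for these numbers, so the result remains a description of the read-out and no more.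

The compounds shown leave open how morpholin-4-yl, a simple open-chain amine such as dimethylamino or a carboxylic acid would read on the same carbonyl carbon in this assay. They also leave open whether compound 3 and compound 4 would remain this close in any other assay or on another core.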